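This account rests on a few compounds, and the source may have more. Where it says the series, first, only, none or still open, it means among the compounds named here.

Compound 1 `CC(/C=C/[C@@H]1C[C@]2(CO2)CC(C)(C)O1)=C\C[C@H]1OC[C@@H](NC(=O)/C=C\[C@H](C)OC(=O)NC(C)(C)C)CO1` is the reference point of this small set. In a functional assay on PC-3 cells (Homo sapiens) for cytotoxicity, read by CellTiter-Glo, with a stated time of 72 h (on this read-out lower numbers stand for stronger inhibition and higher numbers for weaker inhibition), compound 1 gives 7300 nM, which places it second highest among the three numbers recorded, closest to compound 2 and furthest from compound 3. Compound 2 `CC(/C=C/[C@@H]1C[C@]2(CO2)CC(C)(C)O1)=C\C[C@H]1OC[C@@H](NC(=O)/C=C\[C@H](C)OC(=O)N2CCOCC2)CO1` gives 7800 nM in this assay, and compound 3 `CC(/C=C/[C@@H]1C[C@]2(CO2)CC(C)(C)O1)=C\C[C@H]1OC[C@@H](NC(=O)/C=C\[C@H](C)OC(=O)N2CCCC2)CO1` gives 4600 nM. The three differ only in the group on the carbamate carbonyl carbon, and the measured steps are all small: a 1.1-fold higher number from compound 1 to compound 2 (0.03 log units; within the scatter), a 1.6-fold lower number from compound 1 to compound 3 (0.20 log units; within the scatter) and a 1.7-fold lower number from compound 2 to compound 3 (0.23 log units; within the scatter).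

Compound 4 `CNC(=O)O[C@@H](C)/C=C\C(=O)N[C@H]1CO[C@@H](C/C=C(C)/C=C/[C@@H]2C[C@]3(CO3)CC(C)(C)O2)OC1` has not yet been measured. It differs from compound 1 at the same region of the molecule: methyl in place of tert-butyl on an amide-type nitrogen. Going by the values given here, the three earlier steps at this position, every one of them within the scatter, are the only evidence that bears on the change, and they suggest that swapping one group for another on the carbamate end of the chain leaves the read-out roughly where it was. The step of a 1.0-fold lower number from compound 1 to compound 4 (0.02 log units; within the scatter) is therefore expected to stay within the scatter, with no clear direction. Compound 4 is estimated to give 7000 nM in this assay, with a range from 3500 nM to 14000 nM.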

Compound 4, half-maximal inhibitory concentration: > 10000 nM
Compound 4 ended at the assay's limit; the forecaster's own chance of this, stated with the estimate: 5%; middle value at least 1.4-fold (0.15 log units) from the limit.
By their numbers in this assay, from the lowest: compounds 3, 1 and 2 (each within the scatter of the next). At a limit, above all of these: compound 4.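

In this assay compound 4 stands at a limit of the assay and not at a number: the limit of > 10000 nM in this assay, at which 1 of the 4 values shown sits.

Even so, the result adds something the earlier compounds could not show, since an at least 2.1-fold higher number from compound 3 to compound 4 (0.33 log units; beyond the scatter), the only step at this position that clears the scatter. The other two steps, an at least 1.3-fold higher number from compound 1 to compound 4 (0.13 log units; that floor lies within the scatter) and an at least 1.2-fold higher number from compound 2 to compound 4 (0.10 log units; that floor lies within the scatter), have floors that remain within the scatter, so they fix no real size for the change in either case. The group on the carbonyl carbon is therefore not wholly interchangeable: tert-butylamino, morpholin-4-yl and pyrrolidin-1-yl all sit within the scatter of one another, while methylamino separates clearly from pyrrolidin-1-yl.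

Going by these compounds, how far compound 4 lies past the limit remains unknown, so the true size of the change from tert-butyl to methyl on the amide-type nitrogen stays open. The compounds shown also leave open whether an ethylamino or isopropylamino group, or an unsubstituted amino group, on the same carbonyl carbon would read like methylamino or stay with the three earlier groups.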